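The compounds below may be only part of what the source reports. "The series", "measured", "known", "first", "only" and "open" are said of these compounds alone.

Of the compounds shown here, two that share a core have so far been measured in an assay for inhibition of histone-lysine N-methyltransferase, H3 lysine-79 specific (Homo sapiens), read by scintillation counting, with stated times of 15 min and 60 min, tested at 50 uM, in the presence of a further agent that is not named here; on this read-out lower numbers stand for a weaker effect and higher numbers for a stronger effect at the one concentration tested. Compound 1 `Fc1cccc(-c2nnc3sc(/C=C/c4ccco4)nn23)c1` gives 22% in this assay, the lower of the two numbers. Compound 2 `c1ccc2c(Cc3nn4c(-c5ccoc5)nnc4s3)cccc2c1` differs from compound 1 in several places. In this assay compound 2 gives 59%, a number that lies above that of compound 1 by a gap beyond the usual scatter. Compound 3 `Cc1cccc(-c2nnc3sc(/C=C/c4ccco4)nn23)c1` has not yet been measured. It differs from compound 1 in a single place: methyl in place of fluoro on an aromatic carbon. Among the compounds with values here, no measured pair in this assay shows what this kind of change does, so no step can be read from the data, and a small step is expected, in either direction or none beyond the scatter, with the expected step being a number 3 percentage points higher from compound 1 to compound 3 (within the scatter). Compound 3 is thus estimated to give 25% in this assay, within a range from 8% to 45%.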

Compound 3, a percentage reported as inhibition, at one concentration (the size of the read-out at that concentration, not a potency): 69%
Compound 3: middle estimate off by 44 percentage points, on the low side; the whole stated range lies below it.
By their numbers in this assay, from the lowest: compound 1; then compounds 2 and 3 (each within the scatter of the next).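

Exchanging fluoro for methyl on this aromatic carbon, meta to a large group, is far from a neutral swap: in this assay the result is a number 47 percentage points higher from compound 1 to compound 3 (beyond the scatter). Both groups have just one heavy atom and neither counts as a hydrogen-bond donor or acceptor, so at this position a very small edit can carry a large step, something the earlier pair, which differs in several places, could not show. Nothing among the data shown explains why the step is so large.

As far as these compounds go, it remains open how the read-out responds to other groups at this position, such as chloro, methoxy, an amine or a longer chain like ethyl. Within the data shown here, it is also open whether methyl in place of fluoro gives a similar step elsewhere on the ring or on another core, as only this one pair shows the change.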